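The compounds below may be only part of what the source reports. "The series", "measured", "known", "first", "only" and "open" are said of these compounds alone.

Measured so far in a functional assay on K562 cells (Homo sapiens) for antiproliferative activity, with a stated time of 72 h; a higher number here means a weaker inhibitor, a lower number a stronger inhibitor:
compound 1, `OC[C@H]1O[C@@H](n2cnc3c(NCc4ccc(Cl)cc4)ncnc32)[C@H](O)[C@@H]1O`, gives 218000 nM.
compound 2, `COc1cccc(CNc2ncnc3c2ncn3[C@@H]2O[C@H](CO)[C@@H](O)[C@H]2O)c1`, gives > 166000 nM, which is a limit of the assay.
compound 3, `OC[C@H]1O[C@@H](n2cnc3c(NCc4ccc(F)c(F)c4F)ncnc32)[C@H](O)[C@@H]1O`, gives > 166000 nM, which is a limit of the assay.

Within the data shown here, compound 1 is the only member of the set with a number in this assay; the other two values sit at the limit of > 166000 nM in this assay, at which 2 of the 3 values shown sit. For that reason none of the three single-point steps can be sized: a step that the limit leaves unreadable from compound 1 to compound 2, a step that the limit leaves unreadable from compound 1 to compound 3 and a step that the two limits leave unreadable from compound 2 to compound 3 all run into the limit of > 166000 nM in this assay, at which 2 of the 3 values shown sit, and give no direction and no magnitude.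

Compound 4, `OC[C@H]1O[C@@H](n2cnc3c(NCc4c(F)ccc(F)c4F)ncnc32)[C@H](O)[C@@H]1O`, differs from compound 1 in 2,3,6-trifluorophenyl in place of 4-chlorophenyl on a saturated chain carbon bound to a nitrogen on an aromatic ring. The closest measured comparison is a step that the limit leaves unreadable from compound 1 to compound 3, which also exchanges the 4-chlorophenyl for a trifluorophenyl and reads as unresolved. Among the measured compounds shown here, with no sized step available, no movement beyond the scatter can be argued for in either direction, and the expectation is that compound 4 stays in the same weak region as compound 1, with a real chance that this assay again reports only a limit. Compound 4 is therefore estimated at 200000 nM, in the range 90000 nM to 500000 nM. The estimate corresponds to an expected step of a 1.1-fold lower number from compound 1 to compound 4 (0.04 log units; within the scatter).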

Compound 4, half-maximal inhibitory concentration: > 166000 nM
Compound 4 ended at the assay's limit; the forecaster's own chance of this, stated with the estimate: 50%; the middle value is on the limit's open side.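

In this assay compound 4 gives > 166000 nM, which is a limit of the assay. No step linking compound 4 to compound 1, compound 2 or compound 3 can be read: the limit of > 166000 nM in this assay, at which 3 of the 4 values shown sit.

As far as these compounds go, whether the four substituted phenyl groups differ at all in this assay remains open.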